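The compounds below may be only part of what the source reports. "The series", "measured", "known", "first", "only" and "open" are said of these compounds alone.

- compound 1 `N#Cc1nc2c(-c3nc4ccccc4[nH]3)c(N)n(CCN3CCCC3)c2nc1C#N` with 6480 nM
- compound 2 `CN1CCN(CCn2c(N)c(-c3nc4ccccc4[nH]3)c3nc(C#N)c(C#N)nc32)CC1` with 6550 nM
- compound 3 `CCCn1c(N)c(-c2nc3ccccc3[nH]2)c2nc(C#N)c(C#N)nc21` with > 50000 nM (a limit)

Among the compounds with values here, in a functional assay on K562 cells (Homo sapiens) for antiproliferative activity, read by MTT assay, with a stated time of 48 h (on this read-out lower numbers stand for stronger inhibition and higher numbers for weaker inhibition), compound 1 stands level with compound 2, its only neighbour with a true number. Exchanging 4-methylpiperazin-1-yl for pyrrolidin-1-yl gives a 1.0-fold higher number from compound 1 to compound 2 (0.00 log units; within the scatter) here. Methyl is different: it gives an at least 7.7-fold higher number from compound 1 to compound 3 (0.88 log units; beyond the scatter) and an at least 7.6-fold higher number from compound 2 to compound 3 (0.88 log units; beyond the scatter) in this assay.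

Compound 4 `CCN(CC)CCCn1c(N)c(-c2nc3ccccc3[nH]2)c2nc(C#N)c(C#N)nc21` differs from compound 1 as follows: (diethylamino)methyl in place of pyrrolidin-1-yl on a saturated chain carbon, two bonds along the chain from an aromatic nitrogen. In words, (diethylamino)methyl replaces pyrrolidin-1-yl on a saturated chain carbon, two bonds along the chain from an aromatic nitrogen. Compound 4 keeps a nitrogen-bearing group, so the exchange between compound 1 and compound 2 is the closer guide, not the steps to methyl. No step beyond the scatter is therefore expected, and the estimated outcome is a 1.1-fold lower number from compound 1 to compound 4 (0.03 log units; within the scatter). Compound 4 is expected at 6000 nM, with an estimated range of 2500 nM to 16000 nM.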

Compound 4, half-maximal inhibitory concentration: 1800 nM
Estimate against measurement, compound 4: 3.3-fold (0.52 log units) above, and the stated range ends above it.
By their numbers in this assay, from the lowest: compound 4; then compounds 1 and 2 (each within the scatter of the next). At a limit, above all of these: compound 3.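

In this assay the choice among amine-bearing chains now shows: the change to 3-(diethylamino)propyl gives a 3.6-fold lower number from compound 1 to compound 4 (0.56 log units; beyond the scatter) and a 3.6-fold lower number from compound 2 to compound 4 (0.56 log units; beyond the scatter), whereas the two earlier amines stood level. Diethylamino on the propyl chain also gives an at least 27-fold lower number from compound 3 to compound 4 (1.44 log units; beyond the scatter). That step is read against the value of compound 3, which is a limit: the limit of > 50000 nM in this assay, at which 1 of the 4 values shown sits. On these data alone, what stays open is whether the gain follows the diethylamino group or the chain length; a 2-(diethylamino)ethyl chain and a 3-(pyrrolidin-1-yl)propyl chain would separate the two.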